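This account rests on a few compounds, and the source may have more. Where it says the series, first, only, none or still open, it means among the compounds named here.

Three compounds that share one core and differ only in the ring attached to an aromatic carbon have been tested in an ADME assay on BJ cells (Homo sapiens) for cytotoxicity, read by CellTiter-Glo and resazurin assay, with a stated time of 72 h; a lower number here means that less compound is needed, a higher number that more compound is needed for the effect. Compound 1 `CC(C)N(Cc1cccc(OCCCCCC(=O)O)c1)C(=O)c1ccc(-c2ccncc2)cc1` carries a pyridin-4-yl group there; in this assay compound 1 gives > 26000 nM, which is a limit of the assay and not a number. Compound 2 `CC(C)N(Cc1cccc(OCCCCCC(=O)O)c1)C(=O)c1ccc(-c2ccsc2)cc1` carries a thiophen-3-yl group; in this assay compound 2 gives > 26000 nM, again a limit rather than a number. Compound 3 `COc1cc(F)cc(-c2ccc(C(=O)N(Cc3cccc(OCCCCCC(=O)O)c3)C(C)C)cc2)c1` carries a 3-fluoro-5-methoxyphenyl group; in this assay compound 3 gives > 26000 nM, also a limit. Compound 2 thus stands where the other two stand, and all three values sit at the limit of > 26000 nM in this assay, at which 3 of the 3 values shown sit. The steps between them, a step that the two limits leave unreadable from compound 1 to compound 2, a step that the two limits leave unreadable from compound 1 to compound 3 and a step that the two limits leave unreadable from compound 2 to compound 3, cannot be read in size or direction.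

Compound 4 `CC(C)N(Cc1cccc(OCCCCCC(=O)O)c1)C(=O)c1ccc(-c2cccc(Cl)c2)cc1` is not yet measured. It differs from compound 2 in one place: 3-chlorophenyl in place of thiophen-3-yl on an aromatic carbon. All three measured steps bear on this change, as each swaps the ring on an aromatic carbon, yet none gives a readable size. No step beyond the scatter is therefore expected in this assay, and the step from compound 2 to compound 4 is estimated as a step that the limit leaves unreadable from compound 2 to compound 4. For compound 4 the estimated value in this assay is 30000 nM, with a range from 15000 nM to 80000 nM, most likely once more reported only as a limit.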

Compound 4, half-maximal effective concentration: > 21900 nM
Compound 4 ended at the assay's limit; the forecaster's own chance of this, stated with the estimate: 85%; the middle value lies beyond the limit too.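

In this assay compound 4 gives > 21900 nM, again a limit of the assay and not a number. Its steps to compound 1, compound 2 and compound 3 therefore cannot be read in size or direction. The compounds shown leave open whether any ring at this place on the shared core would give a readable value in this assay.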